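This account rests on a few compounds, and the source may have more. Where it says the series, first, only, none or still open, it means among the compounds named here.

The series is followed in an ADME assay on MT4 cells (Homo sapiens) for cytotoxicity, read by MTT assay, with a stated time of 96 h; on this read-out lower numbers stand for higher toxicity in this test and higher numbers for lower toxicity in this test. Compound 1 `COc1ccc2c(=O)c(Cc3c(OC(C)=O)ccc4ccc(=O)oc34)c(N3CCCC3)oc2c1` reaches only a limit of this assay, > 100000 nM, so no number stands for it. Among the measured compounds shown here, compound 2 `CC(=O)Oc1ccc2c(C)cc(=O)oc2c1Cc1c(C)n(C)c2ccccc12` gives 24000 nM in this assay, the one number in the set. Compound 2 therefore stands at the single measured point, while the remainder of the set sits at the limit of > 100000 nM in this assay, at which 1 of the 2 values shown sits, which places compound 1 beyond a comparison of numbers.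

Compound 3 `CC(=O)Oc1ccc2c(C)cc(=O)oc2c1Cc1c(C)[nH]c2ccccc12` is not yet measured in this assay. It differs from compound 2 by hydrogen in place of methyl on an aromatic nitrogen. For the measured compounds named here, no measured pair in the set makes this change, so no step size is known for it from the data. The step from compound 2 to compound 3 is expected to be small, in no set direction, and to stay within the usual scatter, which as an estimate is a 1.3-fold higher number from compound 2 to compound 3 (0.10 log units; within the scatter). For compound 3 the expected value in this assay is 30000 nM, with a range from 9000 nM to 100000 nM; a limit rather than a number is possible for compound 3 as well.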

Compound 3, half-maximal cytotoxic concentration: 41000 nM
For compound 3 the middle estimate is 1.4-fold (0.14 log units) below the measured one; measured number inside the range.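

In this assay the series now has its first measured step, a 1.7-fold higher number from compound 2 to compound 3 (0.23 log units; within the scatter), for hydrogen in place of methyl on an aromatic nitrogen. The earlier compounds shown here gave no reading at this place; now the methyl on this nitrogen, with its one heavy atom, can be exchanged for hydrogen and compound 2 and compound 3 still cannot be told apart on this read-out, so neither ranks over the other. Nothing measured in this set gives a reason for this result.

Going by these compounds, whether a group larger than methyl on this nitrogen, such as an ethyl group, a longer chain ending in an amine or a chain carrying a carboxylic acid, would move the number beyond the usual scatter stays open, since the only substituents compared here are methyl and hydrogen. Among the compounds shown here, compound 1 differs from the other compounds in more than one place and stands at a limit, not a number, so it gives no further step for this position: the limit of > 100000 nM in this assay, at which 1 of the 3 values shown sits.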